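This account rests on a few compounds, and the source may have more. Where it says the series, first, only, none or still open, it means among the compounds named here.

Measured in a functional assay on PC-3 cells (Homo sapiens) for inhibition, read by sulforhodamine B assay, with a stated time of 72 h; a higher number here means a weaker inhibitor, a lower number a stronger inhibitor:
- compound 1 `Nc1sc(-c2ccc(Cl)cc2)c(-c2ccc(Cl)cc2)c1C(=O)Nc1ccccc1`: > 50000 nM (a limit)
- compound 2 `CCOC(=O)Nc1sc(-c2ccc(Cl)cc2)c(-c2ccc(Cl)cc2)c1C(=O)NC1CC1`: 27600 nM
- compound 3 `CCN(CC)CCNC(=O)Nc1sc(-c2ccc(Cl)cc2)c(-c2ccc(Cl)cc2)c1C(=O)NC1CC1`: "not determined" (no result reported)

Compound 1 has no number of its own in this assay. Its entry, > 50000 nM, is a limit of the assay. the limit of > 50000 nM in this assay, at which 1 of the 3 values shown sits, is the only other thing the data say about its position. Compound 2 gives the sole numerical result in the set, 27600 nM, while compound 3 gives "not determined" (no result reported).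

The next compound to be tested is compound 4 `CN1CCN(C(=O)c2c(N)sc(-c3ccc(Cl)cc3)c2-c2ccc(Cl)cc2)CC1`, which keeps the core of compound 1 and changes only the amide. The change is 4-methylpiperazin-1-yl in place of anilino on a carbonyl carbon.

Within the data shown here, no measured pair in the set isolates a change of this kind, so the expectation rests on little. Among the measured compounds shown here, compound 2, at 27600 nM, is the only guide to how far a compound of this family gets in this assay. A small step towards stronger inhibition is expected, if the assay shows any step at all, and compound 4 may well end at a limit too. The expected change is an at least 1.6-fold lower number from compound 1 to compound 4 (0.22 log units; that floor lies within the scatter). Compound 4 is estimated at 30000 nM, with an expected range from 12000 nM to 50000 nM.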

Compound 4, half-maximal inhibitory concentration: 13100 nM
Compound 4: middle estimate off by 2.3-fold (0.36 log units), on the high side, within the range that was stated.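

In this assay, putting 4-methylpiperazin-1-yl in place of anilino on the carbonyl carbon gives an at least 3.8-fold lower number from compound 1 to compound 4 (0.58 log units; beyond the scatter), the first single change in the set shown to move the read-out beyond the usual scatter. The two groups differ in more than one way: the amide hydrogen is gone, and a six-membered non-aromatic ring with two hetero atoms replaces a six-membered aromatic ring of carbon only, and the result alone does not tell which of these differences matters. The true size of the step stays open on one side, since the entry for compound 1 is a limit and not a number: the limit of > 50000 nM in this assay, at which 1 of the 4 values shown sits.

The compounds shown leave open whether the second ring nitrogen is needed at all, a question that a piperidine, a morpholine or an open-chain dimethylamine on the same carbonyl carbon would address. They also leave open whether the step from anilino to 4-methylpiperazin-1-yl would hold if a fluorine or a methoxy group took the place of the chlorine on the aromatic rings of the shared core.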